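The source may hold more compounds than are shown below. What is called first, only, known or untested is meant among the compounds shown, and "the series" means these compounds.

Measured so far in a functional assay on MCF-10A cells (Homo sapiens) for antiproliferative activity, with a stated time of 48 h; a higher number here means that more compound is needed for the effect, a lower number that less compound is needed:
Compound 1 `COc1ccc2nc(C)cc(NCc3ccccc3)c2c1`: 28600 nM
Compound 2 `COc1ccc2nc(C)cc(NCc3ccccc3OC)c2c1`: 29500 nM

Among the measured compounds shown here, these two values lie within the scatter of each other, so compound 2 stands level with compound 1, its only measured neighbour. Compound 3 `COc1ccc2nc(C)cc(NCc3ccccc3CO)c2c1` carries hydroxymethyl in place of methoxy on an aromatic carbon, ortho to a large group (hydroxymethyl in place of methoxy on an aromatic carbon). For the measured compounds named here, the only measured step that touches this group is the one that put methoxy in place of hydrogen, a 1.0-fold higher number from compound 1 to compound 2 (0.01 log units; within the scatter). Going by the values given here, that step shows no change, but no measured pair swaps methoxy for hydroxymethyl, so the evidence is thin and the range must stay wide. The expected step is a 1.0-fold higher number from compound 2 to compound 3 (0.01 log units; within the scatter), which means no shift beyond the scatter in this assay. For compound 3 the estimated value is 30000 nM, with an expected range of 13000 nM to 70000 nM.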

Compound 3, half-maximal effective concentration: 25900 nM
Compound 3: middle estimate off by 1.2-fold (0.06 log units), on the high side; measured number inside the range.
By their numbers in this assay, from the lowest: compounds 3, 1 and 2 (each within the scatter of the next).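

On an aromatic carbon ortho to a large group, hydroxymethyl in place of methoxy gives a 1.1-fold lower number from compound 2 to compound 3 (0.06 log units; within the scatter) in this assay, so a hydrogen-bond donor at this place, which methoxy lacks, makes no difference that can be told from the scatter. Hydroxymethyl in place of hydrogen gives a 1.1-fold lower number from compound 1 to compound 3 (0.04 log units; within the scatter), so hydrogen, methoxy and hydroxymethyl now all stand level at this position, which widens the single earlier comparison to three groups. Nothing available explains why these three groups read alike.

As far as these compounds go, it remains open whether any group at this place can move the number beyond the scatter, for instance an amine, a carboxylic acid or a longer chain. The compounds shown also leave open whether the same level picture holds on the other carbons of this ring or with changes to the shared core.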